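A swapped amine at the limit of a cell test

The source may report more compounds than this note shows. Statements on the series, on what has been measured and on what is new or still open speak of the compounds shown alone.

Compound 1 `CCN(C)c1nc(Cc2c(F)cccc2F)cc(=O)[nH]1` gives > 89000 nM as a limit
Compound 2 `O=c1cc(Cc2c(F)cccc2F)nc(N2CCCC2)[nH]1` gives > 86000 nM as a limit
Compound 3 `Cc1c(Cc2c(F)cccc2F)nc(N(C)c2ccccc2)[nH]c1=O` gives > 73000 nM as a limit

All three results come from an ADME assay on MT4 cells (Homo sapiens) for cytotoxicity, read by MTT assay, with a stated time of 4 days (on this read-out lower numbers stand for higher toxicity in this test and higher numbers for lower toxicity in this test), and none of them is an exact number. Compound 3 stands at > 73000 nM in this assay, and this is a limit. The other two values shown are limits as well, so compound 3 cannot be ranked against them.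

Compound 4 `Cc1c(Cc2c(F)cccc2F)nc(N2CCCC(C)C2)[nH]c1=O` keeps the rest of compound 3 and changes one group (3-methylpiperidin-1-yl in place of methyl(phenyl)amino on an aromatic carbon). Here 3-methylpiperidin-1-yl takes the place of methyl(phenyl)amino on an aromatic carbon between two ring nitrogen atoms.

The closest measured change is a step that the two limits leave unreadable from compound 1 to compound 2, where pyrrolidin-1-yl takes the place of ethyl(methyl)amino. Its size gives no guide to the new step. Since compound 3 sits at > 73000 nM as a limit, no step beyond the usual scatter is expected in this assay. Compound 4 is expected to return a limit as well. The expected change is a step that the limit leaves unreadable from compound 3 to compound 4, and this is only an estimate. Compound 4 is estimated at 75000 nM (expected range 30000 nM to 120000 nM).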

Compound 4, half-maximal cytotoxic concentration: > 75000 nM
Compound 4: no number, only a limit (the forecaster's own chance of this, stated with the estimate: 75%); the middle value lies on the limit itself.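

Compound 3 and compound 4 each return only a limit, not a number, and the step between them cannot be read. The compounds shown leave open what concentration of any of them would be toxic to the cells, and whether exchanging one amine group for another changes that concentration at all.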